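A few compounds are considered here, and "the series" means these few. Any claim that something is new, unique, unknown or untested is made for them only; others in the source may bear on it.

Measured compounds:
compound 1 `CN1C(=O)C=C(Cl)C1(O)c1ccccc1` — 2500 nM
compound 2 `CC(C)CN1C(=O)C=C(Cl)C1(O)c1ccc(Cl)cc1` — 8 nM
compound 3 `CCCCCCN1C(=O)C=C(Cl)C1(O)c1ccc(Cl)cc1` — 3600 nM

In an assay on cell membranes for displacement of a labelled ligand from Cholecystokinin receptor type A (Rattus norvegicus), read by CCK-8 assay, with a stated time of 2 h (on this read-out higher numbers stand for weaker inhibition and lower numbers for stronger inhibition), compound 1 gives 2500 nM, the second highest of the three numbers; the value of compound 3, 3600 nM, sits within the scatter of it, while compound 2, at 8 nM, lies far lower. Compound 4 `O=C1C=C(Cl)C(O)(c2ccccc2)N1Cc1ccccc1` arises from compound 1 by phenyl in place of hydrogen on a saturated chain carbon bound to an amide-type nitrogen in a ring.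

Within the data shown here, only one measured step touches the same place, the chain on the saturated carbon bound to the ring nitrogen: a 450-fold higher number from compound 2 to compound 3 (2.65 log units; beyond the scatter). That single step shows that what sits on this carbon can move the number a great deal, but two compounds with different chains cannot tell in which direction a phenyl would move it, and compound 2 also carries a chlorine on its aromatic ring that compound 1 and compound 4 lack. A change of some size in this assay is therefore expected, with the direction uncertain, and a step of a 2.5-fold lower number from compound 1 to compound 4 (0.40 log units; beyond the scatter) is the estimate here. For compound 4 a value of 1000 nM is expected, with a wide range from 80 nM to 8000 nM.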

Compound 4, half-maximal inhibitory concentration: 800 nM
Compound 4: the middle estimate sits 1.3-fold (0.10 log units) above what was measured; measured number inside the range.
By their numbers in this assay, from the lowest: compound 2; then compound 4; then compounds 1 and 3 (each within the scatter of the next).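

In this assay, the step from methyl to benzyl gives a 3.1-fold lower number from compound 1 to compound 4 (0.49 log units; beyond the scatter), so on the core of compound 1 an added phenyl at this place lowers the number by a modest amount rather than raising it. The earlier step, a 450-fold higher number from compound 2 to compound 3 (2.65 log units; beyond the scatter), compared two different chains on a core with a chlorine on its aromatic ring, and so gave no direction for this change; the new step is both smaller and the first to isolate phenyl in place of hydrogen. Nothing available explains why the number falls here.

Still open, from the compounds shown here alone, is whether benzyl would give a similar step on the chlorine-bearing core of compound 2. Also open, going by these compounds, is how a longer chain ending in phenyl, or a chain ending in an amine or a carboxylic acid, would read at this place.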